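Benzyl in place of isopropyl: a step to estimate

This account rests on a few compounds, and the source may have more. Where it says the series, first, only, none or still open, it means among the compounds named here.

- Compound 1 `CC(=O)c1c(C)[n+]([O-])c2cc(-n3ccnc3)c(F)cc2[n+]1[O-]`: 77700 nM
- Compound 2 `Cc1c(C(=O)OC(C)C)[n+]([O-])c2cc(F)c(-n3ccnc3)cc2[n+]1[O-]`: 77700 nM

Level with compound 1 in an ADME assay on J774.A1 cells (Mus musculus) for cytotoxicity, read by MTT assay, with a stated time of 72 h (a higher number here means a weaker inhibitor, a lower number a stronger inhibitor), compound 2 reads 77700 nM. The next compound, compound 3 `Cc1c(C(=O)OCc2ccccc2)[n+]([O-])c2cc(F)c(-n3ccnc3)cc2[n+]1[O-]`, carries benzyl in place of isopropyl on an oxygen next to a carbonyl group. Among the compounds with values here, only one measured step can guide the estimate. It put isopropoxy in place of methyl on a carbonyl carbon, and it reads no change at the digits printed from compound 1 to compound 2 (within the scatter). Within the data shown here, that is a different swap, so it offers only limited guidance, and no measured compound here carries a benzyl group. The new ring therefore leaves real uncertainty, but no step beyond the scatter is expected in this assay. The expected step is a 1.2-fold lower number from compound 2 to compound 3 (0.08 log units; within the scatter). The estimate for compound 3 is 65000 nM, with an expected range from 30000 nM to 120000 nM.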

Compound 3, half-maximal inhibitory concentration: 77700 nM
Compound 3: the middle estimate sits 1.2-fold (0.08 log units) below what was measured; the range from low to high includes it.
By their numbers in this assay, from the lowest: compounds 1, 2 and 3 (each within the scatter of the next).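

In this assay, within the data shown here, benzyl in place of isopropyl on an oxygen next to a carbonyl group gives no change at the digits printed from compound 2 to compound 3 (within the scatter) and this is the first step here that brings a six-membered aromatic ring to this place. Benzyloxy in place of methyl on a carbonyl carbon gives no change at the digits printed from compound 1 to compound 3 (within the scatter) as well. Among these three compounds, then, a larger group carrying a ring leaves the reading where the smaller groups had it.

As far as these compounds go, whether an amine, a carboxylic acid or a longer chain at this place would also read the same stays open. No measurement offered here explains why these readings sit level.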